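Replacing the butylamino group on the carbonyl carbon

This account rests on a few compounds, and the source may have more. Where it says the series, first, only, none or still open, it means among the compounds named here.

Three compounds on the shared core have been run in a functional assay for inhibition of nuclear factor NF-kappa-B complex (Homo sapiens); a higher number here means a weaker inhibitor, a lower number a stronger inhibitor. Compound 1 `COc1ccc2c(c1)OC(c1cc(OC)c(OC)c(OC)c1)C(C(=O)N(C)OC)=C2` gives 11700 nM in this assay. Compound 2 `CCCCNC(=O)C1=Cc2ccc(OC)cc2OC1c1cc(OC)c(OC)c(OC)c1` gives 25500 nM in this assay and stands highest of the two numbers, with compound 1 the nearest neighbour: a 2.2-fold higher number from compound 1 to compound 2 (0.34 log units; beyond the scatter), a modest step that puts butylamino in place of methoxy(methyl)amino on the carbonyl carbon. Compound 3 `CNC(=O)C1=Cc2ccc(OC)cc2OC1c1cc(OC)c(OC)c(OC)c1` sits at the limit of > 50000 nM in this assay, at which 1 of the 3 values shown sits, so its value > 50000 nM is a limit and not a number. The steps towards it read an at least 4.2-fold higher number from compound 1 to compound 3 (0.63 log units; beyond the scatter) and an at least 1.9-fold higher number from compound 2 to compound 3 (0.29 log units; that floor lies within the scatter), the second with a floor inside the scatter.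

Compound 4 `COc1ccc2c(c1)OC(c1cc(OC)c(OC)c(OC)c1)C(C(C)=O)=C2` differs from compound 2 by methyl in place of butylamino on a carbonyl carbon. Among the measured compounds shown here, none of the measured steps bears on this directly: all three vary what sits on the amide-type nitrogen, and compound 4 has no such nitrogen at all. For the measured compounds named here, what the measured steps show is that every change at this position so far has moved the number upward or left it within the scatter, and none has lowered it. No direction is therefore supported beyond the scatter, and the range is set wide, with a real chance that only a limit is returned. Compound 4 is estimated at 30000 nM, with a range of 9000 nM to 100000 nM. The expected step of a 1.2-fold higher number from compound 2 to compound 4 (0.07 log units; within the scatter) lies within the scatter.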

Compound 4, half-maximal inhibitory concentration: 14100 nM
Estimate against measurement, compound 4: 2.1-fold (0.33 log units) above; the range from low to high includes it.
By their numbers in this assay, from the lowest: compounds 1, 4 and 2 (each within the scatter of the next, the first and the last beyond it). At a limit, above all of these: compound 3.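

Taking the amide-type nitrogen away altogether leaves the number indistinguishable from the amides in this assay: methyl on the carbonyl carbon gives a 1.8-fold lower number from compound 2 to compound 4 (0.26 log units; within the scatter) and a 1.2-fold higher number from compound 1 to compound 4 (0.08 log units; within the scatter), so in these three compounds a nitrogen on the carbonyl carbon is not required for a measurable value. Methyl and methylamino on the same carbonyl carbon do separate, with an at least 3.5-fold lower number from compound 3 to compound 4 (0.54 log units; beyond the scatter), so a short group at this place does not by itself go with the weak result of the methylamide. The value of compound 3 is a limit and not a number, which means this step gives only a floor: the limit of > 50000 nM in this assay, at which 1 of the 4 values shown sits.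

Still open, from the compounds shown here alone, is how a carboxylic acid, a primary amide or a longer ketone chain such as pentanoyl would read on this carbonyl carbon, and whether the weak result of compound 3 is specific to methylamino. Also open, going by these compounds, is whether any group at this place can improve beyond the scatter on compound 1, which gives 11700 nM.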